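The source may report more compounds than this note shows. Statements on the series, on what has been measured and on what is new or still open speak of the compounds shown alone.

Series notes, step from compound 3 to compound 4.

Three compounds are in hand. Compound 1 `Nc1ccccc1NC(=O)c1ccc(COc2ccc(Br)cc2)cc1` gives 24400 nM in a functional assay on A549 cells (Homo sapiens) for antiproliferative activity, read by CCK-8 assay, with a stated time of 72 h; on this read-out higher numbers stand for weaker inhibition and lower numbers for stronger inhibition. Compound 2 `O=C(/C=C/c1ccc(CN2CCc3ccccc32)cc1)NO` gives 5480 nM in this assay. Compound 3 `CCCc1ccc(OCc2ccc(C(=O)Nc3ccccc3N)cc2)cc1` gives 5210 nM in this assay. Compound 3 has the lowest of the three numbers; compound 2 sits within the scatter of it, so no order between those two is claimed, while compound 1 lies beyond it: a 4.7-fold lower number from compound 1 to compound 3 (0.67 log units; beyond the scatter).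

Compound 4 `Nc1ccccc1NC(=O)c1ccc(COc2ccc(Cl)cc2)cc1` differs from compound 3 in one place: chloro in place of propyl on an aromatic carbon. For the measured compounds named here, the only step in hand that touches this position is the one from compound 1 to compound 3, where a halogen gave way to propyl and the number fell, as recorded in a 4.7-fold lower number from compound 1 to compound 3 (0.67 log units; beyond the scatter). The present step runs the other way, propyl out and a halogen in, so a rise in the number in this assay of roughly that size is expected, with some allowance that chloro is not bromo. Compound 4 is therefore estimated at 16000 nM, range 7000 nM to 36000 nM, an expected step of a 3.1-fold higher number from compound 3 to compound 4 (0.49 log units; beyond the scatter).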

Compound 4, half-maximal inhibitory concentration: > 32000 nM
Compound 4 was reported as a limit (the forecaster's own chance of this, stated with the estimate: 5%); middle value at least 2.0-fold (0.30 log units) away from the limit.
By their numbers in this assay, from the lowest: compounds 3 and 2 (each within the scatter of the next); then compound 1. At a limit, above all of these: compound 4.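

Compound 4 stands as a limit and not as a number: the limit of > 32000 nM in this assay, at which 1 of the 4 values shown sits.

Chloro in place of propyl gives an at least 6.1-fold higher number from compound 3 to compound 4 (0.78 log units; beyond the scatter), so the higher number on losing propyl now appears with a second halogen and no longer rests on the bromo comparison alone. Chloro in place of bromo gives an at least 1.3-fold higher number from compound 1 to compound 4 (0.11 log units; that floor lies within the scatter), and since that floor lies within the scatter, no order between the two halogens is claimed.

The compounds shown leave open how a longer chain, a methoxy group or an amine at this position would read in this assay, and whether any of these would give a lower number than propyl. Also open, from the compounds shown here alone, is the full size of the step from propyl to chloro, which the limit bounds on one side only.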